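Solubility notes: aryl ring against the oxygen ring

This account rests on a few compounds, and the source may have more. Where it says the series, first, only, none or still open, it means among the compounds named here.

compound 1 `Cc1cc(NCc2ccccn2)n2ncc(-c3cccc(F)c3)c2n1` — 5000 nM
compound 2 `Cc1cc(NCc2ccccn2)n2ncc(-c3c(C)cccc3C)c2n1` — < 5000 nM (a limit)
compound 3 `Cc1cc(NCc2ccccn2)n2ncc(C3=CCOCC3)c2n1` — 171000 nM

In a physicochemical assay for solubility, read by HPLC, using the shake flask method, measured as kinetic solubility, with a stated time of 2 h, at pH 7.4 (on this read-out lower numbers stand for lower solubility and higher numbers for higher solubility), compound 1 gives 5000 nM. Compound 2 reaches only the limit of the method, < 5000 nM, and no number is known for it. Compound 3 gives 171000 nM, the highest of the two numbers measured; compound 1 is the nearest, and the step of a 34-fold higher number from compound 1 to compound 3 (1.53 log units; beyond the scatter) is large and beyond the scatter. The step of an at least 34-fold higher number from compound 2 to compound 3 (1.53 log units; beyond the scatter) is at least as large. For the pair a number no higher from compound 1 to compound 2 (the limit leaves the size open) the limit leaves the size open.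

Compound 4 `Cc1cc(NCc2ccccn2)n2ncc(-c3ccc(F)cc3C)c2n1` is not yet measured. The change is a group of 8 heavy atoms (7 carbon, 1 fluorine; one six-membered aromatic ring of carbon only) in place of a group of 6 heavy atoms (5 carbon, 1 oxygen; one six-membered non-aromatic ring with 1 hetero atom), on an aromatic carbon. This reverses the kind of change that led into compound 3 in both measured steps, where an aromatic carbon ring gave way to the oxygen ring and the number rose sharply. A large fall in this assay is therefore expected, back toward the level of compound 1 and compound 2. Compound 4 is expected to give 4000 nM, with a range from 1000 nM to 15000 nM. The expected step is a 43-fold lower number from compound 3 to compound 4 (1.63 log units; beyond the scatter). Since compound 2 sits at the limit of < 5000 nM in this assay, at which 1 of the 3 values shown sits, compound 4 may likewise return only a limit.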

Compound 4, solubility: 42300 nM
Compound 4: middle estimate off by 11-fold (1.02 log units), on the low side; the measured number lies above the stated range.
By their numbers in this assay, from the lowest: compound 1; then compound 4; then compound 3.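

In this assay the aromatic carbon ring at this position, on an aromatic carbon of the five-membered aromatic ring, does not tie the number to one low level, although the oxygen ring of compound 3 still stands highest: a 4.0-fold lower number from compound 3 to compound 4 (0.61 log units; beyond the scatter). The aryl groups now separate among themselves, with 4-fluoro-2-methylphenyl in place of 3-fluorophenyl giving an 8.5-fold higher number from compound 1 to compound 4 (0.93 log units; beyond the scatter), and 4-fluoro-2-methylphenyl in place of 2,6-dimethylphenyl giving an at least 8.4-fold higher number from compound 2 to compound 4 (0.92 log units; beyond the scatter). The value of compound 2 is a limit and not a number, so only the lower bound of that last step can be read: the limit of < 5000 nM in this assay, at which 1 of the 4 values shown sits.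

Compound 4 differs from compound 1 in both a methyl and the place of the fluorine, so the compounds shown do not tell which of the two goes with the higher number. Also open, on these data alone, is where the number would fall with an amine or a carboxylic acid on the aromatic carbon ring, and whether either group would bring an aryl compound up to the level of compound 3.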